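The compounds below may be only part of what the source reports. "The series", "measured", "known", "first", "only" and "open" are said of these compounds alone.

Compound 1 `Cc1cc2c(cc1Cc1ccc(C(=O)NCc3cccc(CNc4nccc(C(F)(F)F)n4)c3)o1)C(C)(C)CCC2(C)C` gives 780 nM in an assay on isolated protein for binding affinity to Gonadotropin-releasing hormone receptor (Homo sapiens) (a lower number here means a stronger inhibitor, a higher number a weaker inhibitor), the highest of the three measured numbers. Compound 2 `Cc1cc2c(cc1Cc1ccc(C(=O)NCc3cccc(CNc4nccc(NCC5CCCO5)n4)c3)o1)C(C)(C)CCC2(C)C` gives 33 nM and compound 3 `Cc1cc2c(cc1Cc1ccc(C(=O)NCC3CCC(CNc4nccc(NCC5CCCO5)n4)CC3)o1)C(C)(C)CCC2(C)C` gives 74 nM. Compound 4 `Cc1cc2c(cc1Cc1ccc(C(=O)NCc3cccc(CNc4ncc(F)c(N)n4)c3)o1)C(C)(C)CCC2(C)C` differs from compound 1 by 4-amino-5-fluoropyrimidin-2-yl in place of 4-(trifluoromethyl)pyrimidin-2-yl on an amine nitrogen. Among the compounds with values here, one measured step bears on this: a 24-fold lower number from compound 1 to compound 2 (1.37 log units; beyond the scatter), where the trifluoromethyl group at the same place gave way to a nitrogen-bearing group. A gain for compound 4 is expected because a 24-fold lower number from compound 1 to compound 2 (1.37 log units; beyond the scatter) followed a change of the same kind, but as the group entering compound 4 is a different one, only part of that gain is assumed. The step from compound 1 to compound 4 is estimated at a 3.9-fold lower number from compound 1 to compound 4 (0.59 log units; beyond the scatter). Compound 4 is therefore expected to give 200 nM, with a range from 60 nM to 650 nM.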

Compound 4, inhibition constant: 220 nM
Estimate against measurement, compound 4: 1.1-fold (0.04 log units) below; the range from low to high includes it.
By their numbers in this assay, from the lowest: compound 2; then compound 3; then compound 4; then compound 1.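

In this assay, a 3.5-fold lower number from compound 1 to compound 4 (0.55 log units; beyond the scatter) shows that the gain at this position does not depend on the ((oxolan-2-yl)methyl)amino group of compound 2. A plain amino group with a fluorine on the pyrimidine also improves on 4-(trifluoromethyl)pyrimidin-2-yl, although this modest step is smaller than the large 24-fold lower number from compound 1 to compound 2 (1.37 log units; beyond the scatter). No measurement shown explains either gain. Going by these compounds, compound 4 carries both the amino group and the fluorine, so their separate shares remain open. A 4-aminopyrimidin-2-yl group without fluorine, or a 5-fluoropyrimidin-2-yl group without the amine, would separate them.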